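A few compounds are considered here, and "the series" means these few. Any claim that something is new, unique, unknown or untested is made for them only; others in the source may bear on it.

Values so far in a functional assay on HT-29 cells (Homo sapiens) for antiproliferative activity; on this read-out higher numbers stand for weaker inhibition and lower numbers for stronger inhibition:
compound 1 `COc1ccc(S(=O)(=O)N2CCc3cccc(Nc4ccccc4)c32)cc1` gives 343 nM
compound 2 `COc1ccc(S(=O)(=O)N2CCc3cccc(Nc4ccc(F)cc4)c32)cc1` gives 588 nM
compound 3 `COc1ccc(S(=O)(=O)N2CCc3cccc(Nc4ccc([N+](=O)[O-])cc4)c32)cc1` gives 191 nM

Compound 3 lies within the scatter of compound 1. Among the compounds with values here, only one measured step clears the scatter, and that is a 3.1-fold lower number from compound 2 to compound 3 (0.49 log units; beyond the scatter) in this small set.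

The next structure is compound 4 `COc1ccc(S(=O)(=O)N2CCc3cccc(Nc4ccc(C(=O)O)cc4)c32)cc1` which has carboxy in place of nitro on an aromatic carbon, para to a large group. The counted difference reads carboxy in place of nitro on an aromatic carbon in full.

Within the data shown here, three measured steps concern this same place. Two stay within the scatter, namely a 1.7-fold higher number from compound 1 to compound 2 (0.23 log units; within the scatter) and a 1.8-fold lower number from compound 1 to compound 3 (0.25 log units; within the scatter) as measured. The third, a 3.1-fold lower number from compound 2 to compound 3 (0.49 log units; beyond the scatter) as noted, sets the scale for a swap of one group for another here. Among the measured compounds shown here, no compound with carboxy has been measured, so none of these steps tests the change directly, and the range has to stay wide.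

A modest step toward a higher number is expected in this assay, of about the size of the fluoro-to-nitro step but running the other way. The estimated change is a 2.9-fold higher number from compound 3 to compound 4 (0.46 log units; beyond the scatter) on this basis. Compound 4 is estimated at 550 nM with an expected range from 170 nM to 2000 nM.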

Compound 4, half-maximal inhibitory concentration: 2380 nM
Compound 4: the middle estimate sits 4.3-fold (0.64 log units) below what was measured; measured number above the stated range.
By their numbers in this assay, from the lowest: compounds 3, 1 and 2 (each within the scatter of the next, the first and the last beyond it); then compound 4.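

In this assay, within the data shown here, hydrogen, fluoro and nitro at this place, para to a large group, stayed in a narrow band, with only one step among them beyond the scatter. Carboxy breaks out of that band: a 12-fold higher number from compound 3 to compound 4 (1.10 log units; beyond the scatter), the largest step in the series, shows that this position does not tolerate every substituent equally. The weakening holds against the other two compounds as well, with a 4.0-fold higher number from compound 2 to compound 4 (0.61 log units; beyond the scatter) and a 6.9-fold higher number from compound 1 to compound 4 (0.84 log units; beyond the scatter), so compound 4 stands apart from all three earlier compounds, and since nitro and carboxy match in heavy-atom count, with no ring and no net charge, that count does not separate the pair, leaving the elements and the hydrogen-bond donor and acceptor tallies as the counted differences.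

From the compounds shown here alone, whether the free carboxylic acid itself drives the step remains open, and a methyl ester, a primary amide or a hydroxymethyl group at the same place would help separate the acid from the other features of carboxy. Nothing available bears on the reason for the step.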